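The source may report more compounds than this note shows. Statements on the series, on what has been measured and on what is new or still open speak of the compounds shown alone.

Measured so far in a functional assay on MCF7 cells (Homo sapiens) for inhibition; on this read-out higher numbers stand for weaker inhibition and lower numbers for stronger inhibition: compound 1 `CC/C(=C(/c1ccc(/C=C/C(=O)O)cc1)c1cc2ccccc2[nH]1)c1ccccc1C` gives 33 nM; compound 2 `CC/C(=C(/c1ccc(/C=C/C(=O)O)cc1)c1cc2ccccc2[nH]1)c1ccc(C(F)(F)F)cc1` gives 139 nM; compound 3 `CC/C(=C(/c1ccc(/C=C/C(=O)O)cc1)c1cc2ccccc2[nH]1)c1ccc(F)cc1Cl` gives 39 nM.

Compound 3 stands second highest of the three numbers, within the scatter of compound 1 and clearly lower than compound 2. Compound 4 `CC/C(=C(/c1ccc(/C=C/C(=O)O)cc1)c1cc2ccccc2[nH]1)c1ccc(Cl)cc1C#N` differs from it in one place: 4-chloro-2-cyanophenyl in place of 2-chloro-4-fluorophenyl on a double-bonded chain carbon bound to a double-bonded chain carbon and a saturated chain carbon. Among the measured compounds shown here, the steps that bear on this change are a 1.2-fold higher number from compound 1 to compound 3 (0.07 log units; within the scatter) and a 3.6-fold lower number from compound 2 to compound 3 (0.55 log units; beyond the scatter), the second showing that the ring with a single trifluoromethyl gave weaker inhibition than 2-chloro-4-fluorophenyl. Compound 4, like compound 3 and unlike compound 2, carries two ring substituents including a chlorine, so the step of a 1.4-fold higher number from compound 3 to compound 4 (0.15 log units; within the scatter) is expected to stay within the scatter, perhaps slightly higher. Compound 4 is therefore estimated at 55 nM, between 20 nM and 160 nM.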

Compound 4, half-maximal inhibitory concentration: 14 nM
Compound 4: the middle estimate sits 3.9-fold (0.59 log units) above what was measured; measured number below the stated range.
By their numbers in this assay, from the lowest: compound 4; then compounds 1 and 3 (each within the scatter of the next); then compound 2.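

Exchanging the ring at this position still changes inhibition in this assay even among rings carrying two substituents: 4-chloro-2-cyanophenyl gives a 2.8-fold lower number from compound 3 to compound 4 (0.44 log units; beyond the scatter) and also a 2.4-fold lower number from compound 1 to compound 4 (0.37 log units; beyond the scatter), so it beats two rings whose values lie within the scatter of each other. Against the ring with a single trifluoromethyl, the same change gives a 9.9-fold lower number from compound 2 to compound 4 (1.00 log units; beyond the scatter) and is the widest gap here. No measurement shown explains this gain.

The compounds shown leave open whether the nitrile alone accounts for the gain, or whether the chlorine is also needed. They also leave open how an amine or a methoxy group on this ring would compare.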